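From phenyl to 4-methoxyphenyl at the assay limit

A few compounds are considered here, and "the series" means these few. Any claim that something is new, unique, unknown or untested is made for them only; others in the source may bear on it.

Compound 1 `COc1ccc(/C=N/NC(=O)c2cn(C3CC3)c3cc(N/N=C/c4ccc(OC)cc4)c(F)cc3c2=O)cc1` gives <= 25000 nM
Compound 2 `O=C(N/N=C/c1ccccc1)c1cn(C2CC2)c2cc(N3CCNCC3)c(F)cc2c1=O` gives <= 25000 nM

In a functional assay on HL-60 cells (Homo sapiens) for antiproliferative activity, read by MTT assay (on this read-out lower numbers stand for stronger inhibition and higher numbers for weaker inhibition), compound 2 gives <= 25000 nM and this is a limit, not a number. Both measured compounds share one reading (the limit of <= 25000 nM in this assay, at which 2 of the 2 values shown sit) and so neither has an exact value yet. Compound 3 `COc1ccc(/C=N/NC(=O)c2cn(C3CC3)c3cc(N4CCNCC4)c(F)cc3c2=O)cc1` differs from compound 2 in one place (methoxy in place of hydrogen on an aromatic carbon) with methoxy in place of hydrogen on an aromatic carbon. Within the data shown here, no measured step shows what this change does. The expected step (a step that the limit leaves unreadable from compound 2 to compound 3) in this assay is a small move towards stronger inhibition that stays within the usual scatter. For compound 3 the estimated value is 15000 nM with an expected range from 4000 nM to 25000 nM. Compound 3 may again give only a limit.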

Compound 3, half-maximal inhibitory concentration: <= 25000 nM
Compound 3 was reported as a limit (the forecaster's own chance of this, stated with the estimate: 60%); the middle value is on the limit's open side.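

No step can be read between compound 1, compound 2 and compound 3, because each is reported only as a limit: the limit of <= 25000 nM in this assay, at which 3 of the 3 values shown sit. On these data alone, what methoxy in place of hydrogen on an aromatic carbon does in this assay stays open.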